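The source may hold more compounds than are shown below. What is called first, only, known or untested is meant among the compounds shown, and "the series" means these compounds.

Compounds measured in a functional assay on K562 cells (Homo sapiens) for antiproliferative activity, read by MTT assay, with a stated time of 72 h (on this read-out lower numbers stand for stronger inhibition and higher numbers for weaker inhibition), each value being a limit and not a number:

- Compound 1 `COc1cccc(-c2ncnn2-c2cc(OC)c(OC)c(OC)c2)c1`: > 10000 nM
- Compound 2 `COc1cc(-n2ncnc2-c2ccc(Cl)c(Cl)c2)cc(OC)c1OC`: > 10000 nM
- Compound 3 `COc1cc(-n2ncnc2-c2cccc(F)c2)cc(OC)c1OC`: > 10000 nM

All three share the same reading: the limit of > 10000 nM in this assay, at which 3 of the 3 values shown sit. Compound 3 therefore has no number of its own, only the limit > 10000 nM, and no value shown ranks it against the other two.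

The next compound, compound 4 `COc1cc(-n2ncnc2-c2ccc(SC)cc2)cc(OC)c1OC`, carries 4-(methylsulfanyl)phenyl in place of 3-fluorophenyl on an aromatic carbon of a five-membered aromatic ring with 3 nitrogen: 4-(methylsulfanyl)phenyl in place of 3-fluorophenyl on an aromatic carbon.

The measured steps that bear on this change are those that alter the same phenyl group: a step that the two limits leave unreadable from compound 1 to compound 2, a step that the two limits leave unreadable from compound 1 to compound 3 and a step that the two limits leave unreadable from compound 2 to compound 3. None of them has a readable size, so none offers a size to carry over. The entering group also differs from all three groups tried so far.

The expectation in this assay is therefore loose. The estimated step, an at least 3.3-fold lower number from compound 3 to compound 4 (0.52 log units; beyond the scatter), leans toward stronger inhibition, and compound 4 may equally be expected to stay at the limit. For compound 4 the estimated value is 3000 nM, with an expected range of 50 nM to 20000 nM.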

Compound 4, half-maximal inhibitory concentration: 340 nM
The estimate for compound 4 lay 8.8-fold (0.95 log units) above the measured number; the measured number falls inside the stated range.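

In this assay, the group on the aromatic carbon between two ring nitrogen atoms proves able to change the result strongly: 4-(methylsulfanyl)phenyl in place of 3-fluorophenyl gives an at least 29-fold lower number from compound 3 to compound 4 (1.46 log units; beyond the scatter), in place of 3,4-dichlorophenyl it gives an at least 29-fold lower number from compound 2 to compound 4 (1.46 log units; beyond the scatter), and in place of 3-methoxyphenyl it gives an at least 29-fold lower number from compound 1 to compound 4 (1.46 log units; beyond the scatter). Within the data shown here, these are the first readable steps at this position, since the steps among compound 1, compound 2 and compound 3 cannot be read, and the size of each new step is only a minimum because it starts from a limit: the limit of > 10000 nM in this assay, at which 3 of the 4 values shown sit. Compound 4 is the only compound shown with a number of its own, 340 nM, so the shared core can give a measurable result when this phenyl group is changed.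

From the compounds shown here alone, whether the gain belongs to the methylsulfanyl group itself or to where it sits on the phenyl ring stays open, a question that 3-(methylsulfanyl)phenyl or 4-methoxyphenyl would address. Also open, going by these compounds, is whether a longer chain, as in 4-(ethylsulfanyl)phenyl, or an amine in that place would keep compound 4's level of 340 nM.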